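Sulfonyl aryl swaps on the shared core: compound 4

A few compounds are considered here, and "the series" means these few. Any claim that something is new, unique, unknown or untested is made for them only; others in the source may bear on it.

Three measured compounds share one core and differ only in the aryl group on the sulfonyl sulfur. Compound 1 `Cc1ccc(S(=O)(=O)c2cnc3cc(F)ccc3c2N2CCC(C)CC2)cc1C` gives 90% in an assay on isolated protein for displacement of a labelled ligand from metabotropic glutamate receptor 5 (Homo sapiens), with a stated time of 60 min, tested at 1 uM; a higher number here means more inhibition at the concentration tested (going by the name of the read-out), a lower number less inhibition. Compound 2 `CC1CCN(c2c(S(=O)(=O)c3ccc(F)c(Cl)c3)cnc3cc(F)ccc23)CC1` gives 94% in this assay, and compound 3 `COc1ccc(S(=O)(=O)c2cnc3cc(F)ccc3c2N2CCC(C)CC2)cc1` gives 90% in this assay. Compound 3 stands level with compound 1, the two together the lowest of the three numbers, and the step of a number 4 percentage points lower from compound 2 to compound 3 (within the scatter) lies within the scatter. Compound 4 `CC1CCN(c2c(S(=O)(=O)c3ccc(Cl)cc3)cnc3cc(F)ccc23)CC1` is compound 3 with chloro in place of methoxy on an aromatic carbon, set para to a large group. Among the measured compounds shown here, the steps that bear on this change are the two arriving at the 4-methoxyphenyl, no change at the digits printed from compound 1 to compound 3 (within the scatter) and a number 4 percentage points lower from compound 2 to compound 3 (within the scatter), and the one bringing in a chloro-bearing ring, a number 4 percentage points higher from compound 1 to compound 2 (within the scatter); none leaves the scatter. No step beyond the scatter is therefore expected in this assay for compound 4, the expected step being a number 1 percentage points higher from compound 3 to compound 4 (within the scatter). Compound 4 is estimated at 91%, with a range from 83% to 98%.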

Compound 4, a percentage reported as inhibition, at one concentration (the size of the read-out at that concentration, not a potency): 90%
Compound 4: the middle estimate sits 1 percentage points above what was measured; measured number inside the range.
By their numbers in this assay, from the lowest: compounds 1, 3, 4 and 2 (each within the scatter of the next).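

Chloro in place of methoxy on an aromatic carbon, para to a large group, reads no change at the digits printed from compound 3 to compound 4 (within the scatter) in this assay, so exchanging methoxy for the single chlorine atom, with one hydrogen-bond acceptor fewer, produces no step beyond the scatter at this position. The 4-chlorophenyl ring also reads no change at the digits printed from compound 1 to compound 4 (within the scatter) and a number 4 percentage points lower from compound 2 to compound 4 (within the scatter), which places all four aryl groups on the sulfonyl sulfur within the scatter of one another. No measurement here offers an explanation for this flat result.

From the compounds shown here alone, whether an amine, a carboxylic acid or a longer chain such as butoxy in this place would leave the scatter stays open. A read-out at one concentration also leaves any differences in potency among these compounds unresolved.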